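Replacing the Ketone Chain with a Carbamate on the Aryl Oxygen

The compounds below may be only part of what the source reports. "The series", "measured", "known", "first", "only" and "open" are said of these compounds alone.

In a functional assay (trachea) with Rattus norvegicus as the target (on this read-out lower numbers stand for lower potency and higher numbers for higher potency (the scale is a negative logarithm)), compound 1 `COc1ccc2c(c1)C(n1ccccc1=O)=CC(C)(C)O2` gives 5.99, while compound 2 `CC1(C)C=C(n2ccccc2=O)c2cc(OCC(=O)c3ccc(F)cc3)ccc2O1` gives 4.77, the lowest of the two numbers shown. Going by the values given here, the one measured step, a number 1.22 log units lower from compound 1 to compound 2 (beyond the scatter), shows how much potency was lost when a group was placed on that oxygen. Compound 3 `CC1(C)C=C(n2ccccc2=O)c2cc(OC(=O)Nc3ccccc3F)ccc2O1` differs from compound 2 by (2-fluorophenyl)carbamoyl in place of ((4-fluorophenyl)carbonyl)methyl on an oxygen on an aromatic ring. That earlier step bears on the change only loosely, since a group of the same size remains on the same oxygen, so no large move is expected. Compound 3 is therefore estimated at 5, between 4.3 and 5.7, a step of a number 0.23 log units higher from compound 2 to compound 3 (within the scatter) in this assay.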

Compound 3, logarithm of the reciprocal of the active concentration, log(1/C): 4.22
Beside the measured number, compound 3's estimate is 0.78 log units above it; measured number outside the range, below it.
By their numbers in this assay, from the lowest: compound 3; then compound 2; then compound 1.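

In this assay the (2-fluorophenyl)carbamoyl group on this oxygen gives no recovery: the number falls further, a number 0.55 log units lower from compound 2 to compound 3 (beyond the scatter), and the total loss is a number 1.77 log units lower from compound 1 to compound 3 (beyond the scatter). The leaving and entering groups match in heavy-atom count, so that count alone does not set the number at this position. Nothing measured here accounts for the difference. The compounds shown leave open how the step divides between the carbamoyl link and the change from 4-fluorophenyl to 2-fluorophenyl, since both change together. They also leave open how a short chain ending in an amine or a carboxylic acid would read on this oxygen.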